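Swapping methyl for bromo on the shared core

The source may report more compounds than this note shows. Statements on the series, on what has been measured and on what is new or still open speak of the compounds shown alone.

Measured so far:
compound 1, `Cc1ccc(-c2nnc(Nc3ncccn3)o2)cc1`, gives < 20%
compound 2, `Oc1ccccc1-c1nnc(Nc2ncccn2)o1`, gives 58.8%

Of the compounds shown here, two share one core and have been tested in a functional assay, with a stated time of 30 min, tested at 20 uM; a higher number here means more inhibition at the concentration tested (going by the name of the read-out), a lower number less inhibition. For compound 1 the result is only a limit of the assay, < 20%, not a measured number. Compound 2 carries a hydroxy group in place of the methyl and in this assay gives 58.8%. Compound 1 sits at the low end of the two values shown, at the limit (the limit of < 20% in this assay, at which 1 of the 2 values shown sits).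

Compound 3, `Brc1ccc(-c2nnc(Nc3ncccn3)o2)cc1`, has not yet been tested in this assay. It differs from compound 1 by bromo in place of methyl on an aromatic carbon. Among the compounds with values here, no measured pair with this kind of change is available, so the expected step rests only on where compound 1 stands. The step from compound 1 to compound 3 is expected to be a number at least 2 percentage points higher from compound 1 to compound 3 (that floor lies within the scatter), that is a small rise at most, likely within the scatter of repeated measurements. In this assay compound 3 is therefore expected to give about 22%, within a range from 5% to 45%.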

Compound 3, a percentage reported as inhibition, at one concentration (the size of the read-out at that concentration, not a potency): 47.8%
Beside the measured number, compound 3's estimate is 25.8 percentage points below it, outside the stated range (above it).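

In this assay, putting bromo in place of methyl on this aromatic carbon, para to a large group, gives a number at least 27.8 percentage points higher from compound 1 to compound 3 (beyond the scatter). Within the data shown here, the earlier compounds offered no pair with this change, so this is the first sign that the read-out responds to which group sits at this place, even though neither group brings a ring, a hydrogen-bond donor or acceptor, or a net charge. Compound 1 gives < 20%, which is a limit of the assay and not a number, so the step has only a lower bound and its full size stays unknown: the limit of < 20% in this assay, at which 1 of the 3 values shown sits.

The compounds shown leave open whether this rise is particular to bromo or would also appear with other groups at this place, such as chloro, an amine or a carboxylic acid. A single pair also cannot tell why the change matters, or whether the same swap would have a similar effect on a different core.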